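Fluoro-to-bromo exchange at two places in one series

This account rests on a few compounds, and the source may have more. Where it says the series, first, only, none or still open, it means among the compounds named here.

Compound 1 `NC(=O)c1c(NC(=O)c2ccccc2Cl)sc2c1CCN(C(=S)Nc1ccccc1F)C2` and compound 2 `NC(=O)c1c(NC(=O)c2ccccc2Cl)sc2c1CCN(C(=S)Nc1ccccc1Br)C2` share one core; the single difference between them is bromo in place of fluoro on an aromatic carbon, which read one bond further out is (2-fluorophenyl)amino to (2-bromophenyl)amino. In a functional assay on HL-60 cells (Homo sapiens) for antiproliferative activity, with a stated time of 24 h (on this read-out higher numbers stand for weaker inhibition and lower numbers for stronger inhibition), compound 1 gives 4970 nM. In the same assay compound 2 gives 9090 nM. The step is a 1.8-fold higher number from compound 1 to compound 2 (0.26 log units; within the scatter), so the two numbers cannot be told apart.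

Compound 3 `NC(=O)c1c(NC(=O)c2ccccc2F)sc2c1CCN(C(=S)Nc1ccccc1Cl)C2` has the same atoms as compound 1 joined differently; how the two cores differ is not broken down here. In this assay compound 3 gives 12500 nM. Against compound 2 this lies within the scatter; against compound 1 it lies beyond the scatter, with the weaker inhibition on the side of compound 3.

Compound 4 `NC(=O)c1c(NC(=O)c2ccccc2Br)sc2c1CCN(C(=S)Nc1ccccc1Cl)C2` has not been measured. It differs from compound 3 by bromo in place of fluoro on an aromatic carbon, which one bond further out reads ((2-fluorophenyl)carbonyl)amino to ((2-bromophenyl)carbonyl)amino. The place is described in the same words for both pairs, though the surrounding group differs, so the two changes are taken as the same change at a different group. Within the data shown here, only one measured example of it exists.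

For compound 4 in this assay the expected value is 18000 nM, within a range from 8000 nM to 40000 nM, because a 1.8-fold higher number from compound 1 to compound 2 (0.26 log units; within the scatter) was seen for the same change. The step this estimate implies is expected to be a 1.4-fold higher number from compound 3 to compound 4 (0.16 log units; within the scatter), a shift that stays within the usual scatter.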

Compound 4, half-maximal inhibitory concentration: 14600 nM
The estimate for compound 4 lay 1.2-fold (0.09 log units) above the measured number, within the range that was stated.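

Bromo in place of fluoro, here read as ((2-fluorophenyl)carbonyl)amino to ((2-bromophenyl)carbonyl)amino, gives a 1.2-fold higher number from compound 3 to compound 4 (0.07 log units; within the scatter) in this assay, so the two numbers of this pair cannot be told apart. Set beside the earlier exchange on the (2-fluorophenyl)amino group, the new step shows no detectable difference in how the change reads on the two cores: the same change on two cores in this assay, a 1.8-fold higher number (0.26 log units; within the scatter) from compound 1 to compound 2 and a 1.2-fold higher number (0.07 log units; within the scatter) from compound 3 to compound 4, 1.6-fold (0.19 log units) apart, within the scatter of two such steps. This supports only a limited statement, namely that in these two pairs the exchange produces no step beyond the scatter; it does not show that the two steps are truly equal, that the exchange has no effect at all, or that the same result would hold on any further core in the series.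

Still open, on these data alone, is how a methyl, a methoxy or a nitrile in place of the halogen on either phenyl ring would read in this assay, since fluoro and bromo alone cannot show whether any other group at that place moves the number beyond the scatter. Also open, as far as these compounds go, is what an amine or a carboxylic acid on those rings would do, and whether either pair would stay as close under a different read-out.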